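The compounds below may be only part of what the source reports. "The series", "measured", "known", "first", "only" and "open" are said of these compounds alone.

Working notes, series on the shared core of compound 1.

Compound 1 `C[C@@H](O)[C@H](NC(=O)CN(c1ncnc2c1ncn2C1CCCCO1)C1CC1)C(=O)OCc1ccccc1` gives 6.53% in a functional assay on the whole organism (Tail, strain ICR) with Mus musculus as the target, in the tail flick test, with a stated time of 150 min, at a dose of 25 umol/kg by the oral route; on this read-out higher numbers stand for a stronger effect at the one dose given and lower numbers for a weaker effect. Compound 2 `O=C(CN(c1ncnc2c1ncn2C1CCCCO1)C1CC1)N[C@@H](CC(=O)OCc1ccccc1)C(=O)OCc1ccccc1` gives 0.06% in this assay, and compound 3 `C[C@H](NC(=O)CN(c1ncnc2c1ncn2C1CCCCO1)C1CC1)C(=O)OCc1ccccc1` gives 6.01% in this assay. On these three numbers compound 3 sits with compound 1, a number 0.5 percentage points lower from compound 1 to compound 3 (within the scatter), and apart from compound 2 only by a number 6 percentage points higher from compound 2 to compound 3 (within the scatter); none of the three is separated from another beyond the scatter, and a number 6.5 percentage points lower from compound 1 to compound 2 (within the scatter) closes the triangle.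

Compound 4 `CC(C)C[C@H](NC(=O)CN(c1ncnc2c1ncn2C1CCCCO1)C1CC1)C(=O)OCc1ccccc1` has not been measured in this assay. It differs from compound 3 by isopropyl in place of hydrogen on a saturated chain carbon, two bonds along the chain from an amide-type nitrogen and a carbonyl carbon. For the measured compounds named here, the step that bears on this place is the one where a number 6 percentage points higher from compound 2 to compound 3 (within the scatter); the neighbouring exchanges a number 0.5 percentage points lower from compound 1 to compound 3 (within the scatter) and a number 6.5 percentage points lower from compound 1 to compound 2 (within the scatter) are likewise within the scatter. Every change tried at or near this chain carbon has left the read-out where it was, so no step beyond the scatter is expected from compound 3 to compound 4; the expected step is a number 0 percentage points lower from compound 3 to compound 4 (within the scatter). Compound 4 is therefore estimated at 6% in this assay, with a range from 0% to 16%.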

Compound 4, a percentage reported as activity, at one dose (the size of the read-out at that dose, not a potency): 6.47%
For compound 4 the middle estimate is 0.5 percentage points below the measured one; the measured number falls inside the stated range.
By their numbers in this assay, from the lowest: compounds 2, 3, 4 and 1 (each within the scatter of the next).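

In this assay, isopropyl in place of hydrogen on this saturated chain carbon, an entering group of 3 carbon atoms with no ring, gives a number 0.5 percentage points higher from compound 3 to compound 4 (within the scatter) and so extends the flat picture to a branched carbon group. The wider exchanges at the same place behave alike, with a number 6.4 percentage points higher from compound 2 to compound 4 (within the scatter) for isopropyl in place of benzyloxycarbonyl and a number 0.1 percentage points lower from compound 1 to compound 4 (within the scatter) for isobutyl in place of 1-hydroxyethyl, so all four compounds now lie within the scatter of one another. No measurement available here explains this flat result.

Going by these compounds, whether an amine, a carboxylic acid or a longer chain at this chain carbon would move the read-out beyond the scatter remains open. The single dose and single time also leave open whether these compounds differ in potency.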